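Swapping methyl for fluoro on a fused ring

A few compounds are considered here, and "the series" means these few. Any claim that something is new, unique, unknown or untested is made for them only; others in the source may bear on it.

compound 1 `O=c1[nH]c2ccccc2n1CCCN1CCN(S(=O)(=O)c2ccc([N+](=O)[O-])cc2)CC1` — > 10000 nM
compound 2 `Cc1cccc2c1ccn2CCCCN1CCN(C(c2ccccc2)c2ccccc2)CC1` — 5300 nM

In an assay on RPMI-8226 cells for antagonist activity at P2X purinoceptor 7 (Homo sapiens), read by calcium flux (a lower number here means a stronger inhibitor, a higher number a weaker inhibitor), compound 1 gives > 10000 nM, which is a limit of the assay rather than a number. For the measured compounds named here, compound 2 gives 5300 nM in this assay, the only number measured here. Compound 3 `Fc1cccc2c1ccn2CCCCN1CCN(C(c2ccccc2)c2ccccc2)CC1` differs from compound 2 by fluoro in place of methyl on an aromatic carbon. Going by the values given here, no measured pair shows this change, so nothing is known about its effect. The step from compound 2 to compound 3 is expected to be a 1.1-fold lower number from compound 2 to compound 3 (0.03 log units; within the scatter), within the usual scatter. Compound 3 is therefore expected to give 5000 nM in this assay, between 1800 nM and 14000 nM.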

Compound 3, half-maximal inhibitory concentration: 150 nM
Beside the measured number, compound 3's estimate is 33-fold (1.52 log units) above it; measured number below the stated range.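

In this assay, exchanging one heavy atom on the six-membered aromatic ring gives a 35-fold lower number from compound 2 to compound 3 (1.55 log units; beyond the scatter), so this position is highly sensitive to which small group it carries. Before this pair, no two compounds differing in one place existed, so this sensitivity could not be seen. Nothing shown here explains the size of the step.

As far as these compounds go, it remains open whether plain hydrogen, chloro, methoxy or a nitrile at this carbon would match fluoro. From the compounds shown here alone, it also remains open whether fluoro would have a similar effect elsewhere on this ring.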